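A few compounds are considered here, and "the series" means these few. Any claim that something is new, unique, unknown or untested is made for them only; others in the source may bear on it.

Measured so far:

Compound 1 `O=c1cc(/C=N\c2ccccc2O)c2c(OCc3ccccc3)cc(OCc3ccccc3)cc2o1`: in a functional assay, read by spectrophotometry, with a stated time of 1 h (on this read-out lower numbers stand for stronger inhibition and higher numbers for weaker inhibition), compound 1 gives 348000 nM.

Compound 2 `O=c1cc(/C=N\c2ccc(O)cc2)c2ccc(OCc3ccccc3)cc2o1`: in this assay compound 2 gives 233000 nM.

Both numbers are far from strong inhibition, and the gap between compound 1 and compound 2 lies within the scatter of repeated measurements, so nothing separates the two on this read-out; compound 2 simply shows the smaller of the two numbers, and that is all the data say about where it stands.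

The next compound, compound 3 `O=c1cc(/C=N\Nc2ccc([N+](=O)[O-])cc2)c2ccc(OCc3ccccc3)cc2o1`, keeps the shared core of compound 2 and changes one place on it: (4-nitrophenyl)amino in place of 4-hydroxyphenyl on a double-bonded nitrogen. Within the data shown here, no measured pair in this set tells how such a change moves this assay, so there is no step to lean on. Starting from the value of compound 2 in this assay, the expectation is a step from compound 2 to compound 3 of a 1.2-fold lower number from compound 2 to compound 3 (0.07 log units; within the scatter), that is, nothing clearly beyond the scatter in either direction. Compound 3 is therefore expected to give about 200000 nM in this assay, within a range from 60000 nM to 700000 nM.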

Compound 3, half-maximal inhibitory concentration: > 2000000 nM
Compound 3 was reported as a limit; the forecaster's own chance of this, stated with the estimate: 15%; middle value at least 10-fold (1.00 log units) away from the limit.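

Among these compounds, the earlier compounds offered no step at all, so this is the first sign that the group on the double-bonded nitrogen matters in this assay: (4-nitrophenyl)amino in place of 4-hydroxyphenyl gives an at least 8.5-fold higher number from compound 2 to compound 3 (0.93 log units; beyond the scatter). The direction is toward weaker inhibition, starting from a compound that was already far from strong inhibition, so this place does not accept every aromatic group equally. In this assay the value of compound 3 is a limit and not a number, which makes the step a minimum and leaves its true size unknown: the limit of > 2000000 nM in this assay, at which 1 of the 3 values shown sits.

This single step changes two things at once, adding an amino link and replacing the hydroxyl with a nitro group, and the compounds shown do not tell which of the two accounts for the loss. A 4-nitrophenyl group without the amino link, a (4-hydroxyphenyl)amino group, or a ring carrying an amine or a carboxylic acid in the same place would be needed to separate these two parts and to show whether any group here gives stronger inhibition than compound 2.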